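Swapping the hydroxyl position on a pyridine-linked phenyl ring

The source may report more compounds than this note shows. Statements on the series, on what has been measured and on what is new or still open speak of the compounds shown alone.

Compound 1, `Oc1cccc(-c2cc(-c3cccnc3)nc(-c3ccccc3Cl)c2)c1`, gives 0% in an assay on isolated protein for inhibition of DNA topoisomerase 1 (Homo sapiens), with a stated time of 30 min, tested at 100 uM; on this read-out higher numbers stand for a stronger effect at the one concentration tested and lower numbers for a weaker effect.
Compound 2, `Oc1cccc(-c2cc(-c3ccc(Cl)cc3)nc(-c3ccsc3)c2)c1`, gives 11.7% in this assay.
Compound 3, `Oc1ccc(-c2cc(-c3ccsc3)nc(-c3ccccc3Cl)c2)cc1`, gives 4.1% in this assay.

All three numbers in this assay are small, and each lies within the usual scatter of the other two, so none of the three can be called stronger or weaker than another. Compound 3 stands among them with compound 1 as its nearest neighbour and compound 2 as its furthest, both gaps within the scatter.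

Compound 4, `Oc1cccc(-c2cc(-c3ccsc3)nc(-c3ccccc3Cl)c2)c1`, has not yet been measured. It differs from compound 3 in one place: 3-hydroxyphenyl in place of 4-hydroxyphenyl on an aromatic carbon. The same kind of 3-hydroxyphenyl group is already carried by compound 1 and compound 2, whose numbers in this assay sit close to that of compound 3. Within the data shown here, with no measured step to lean on, no change beyond the scatter is expected here. The step expected is a number 0.9 percentage points higher from compound 3 to compound 4 (within the scatter), which is none beyond the scatter. For compound 4 an inhibition of 5% is estimated, with a range from 0% to 15%.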

Compound 4, a percentage reported as inhibition, at one concentration (the size of the read-out at that concentration, not a potency): 0%
The estimate for compound 4 lay 5 percentage points above the measured number; low and high end bracket the measured number.
By their numbers in this assay, from the lowest: compounds 1, 4, 3 and 2 (each within the scatter of the next, the first and the last beyond it).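

Moving the hydroxyl, with 3-hydroxyphenyl in place of 4-hydroxyphenyl, gives a number 4.1 percentage points lower from compound 3 to compound 4 (within the scatter), so this assay does not tell these two groups apart at this position. The two other changes now readable differ in size: 2-chlorophenyl in place of 4-chlorophenyl gives a number 11.7 percentage points lower from compound 2 to compound 4 (beyond the scatter), a modest step and the only one of the three beyond the scatter, while thiophen-3-yl in place of pyridin-3-yl gives no change at the digits printed from compound 1 to compound 4 (within the scatter). Nothing measured here speaks to the cause of any of these steps.

Still open, on these data alone, is whether an amine or a carboxylic acid on this phenyl ring, in place of the hydroxyl, would move the number beyond the scatter. Also open, as far as these compounds go, is how 2-hydroxyphenyl would compare with the two hydroxyphenyl groups seen so far.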